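A few compounds are considered here, and "the series" means these few. Any claim that something is new, unique, unknown or untested is made for them only; others in the source may bear on it.

Compound 2 `COc1ccc(/C=C/C(=O)Nc2cc(Sc3ncn[nH]3)c(O)c3ccccc23)cc1OC` was tested in a functional assay on HCT-116 cells (Homo sapiens) for antiproliferative activity, read by MTT assay, with a stated time of 48 h (a lower number here means a stronger inhibitor, a higher number a weaker inhibitor), and compound 2 gives > 100000 nM, which is a limit of the assay rather than a measured number. Compound 1 `O=C(Nc1cc(Sc2ncn[nH]2)c(O)c2ccccc12)c1ccc2ccccc2c1` shares the same core and in this assay compound 1 gives > 100000 nM, again a limit. Both values shown therefore sit at one point: the limit of > 100000 nM in this assay, at which 2 of the 2 values shown sit. Every number shown is a limit. Compound 2 thus cannot be placed above or below any other compound; it stands where the assay stops counting.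

Compound 3 `O=C(/C=C/c1ccccc1)Nc1cc(Sc2ncn[nH]2)c(O)c2ccccc12` differs from compound 2 in one place: phenyl in place of 3,4-dimethoxyphenyl on a double-bonded chain carbon bound to a double-bonded chain carbon. Going by the values given here, no step between two measured compounds is available to show what such a change does here. The step from compound 2 to compound 3 is expected to be a number no higher from compound 2 to compound 3 (the limit leaves the size open), that is, no change beyond the usual scatter. Compound 3 is expected to give about 100000 nM, with a range from 30000 nM to 300000 nM, and most likely the assay will again report only a limit.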

Compound 3, half-maximal inhibitory concentration: > 100000 nM
Compound 3: a limit, no number; the forecaster's own chance of this, stated with the estimate: 75%; the middle value lies on the limit itself.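

In this assay compound 3 gives > 100000 nM, which is a limit. Going by these compounds alone, no step among compound 1, compound 2 and compound 3 can be read, so the three stay unranked: the limit of > 100000 nM in this assay, at which 3 of the 3 values shown sit. The compounds shown leave open what any of these groups on the shared core does to activity in this assay.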